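Swapping the para group on the cyclopentyl-bound phenyl ring

The source may report more compounds than this note shows. Statements on the series, on what has been measured and on what is new or still open speak of the compounds shown alone.

Measured so far:
Compound 1, `Cc1cccc(C2(CNC(=O)Nc3c(C(C)C)cccc3C(C)C)CCCC2)c1` — 15 nM in an assay on microsomes for inhibition of acyl-CoA:cholesterol acyltransferase (Oryctolagus cuniculus); a higher number here means a weaker inhibitor, a lower number a stronger inhibitor
Compound 2, `CC(C)c1cccc(C(C)C)c1NC(=O)NCC1(c2ccc(CC(C)(C)C)cc2)CCCC1` — 159 nM in this assay
Compound 3, `COc1ccc(C2(CNC(=O)Nc3c(C(C)C)cccc3C(C)C)CCCC2)cc1` — 31 nM in this assay

Compound 3 stands second of the three numbers: compound 1 gives a lower number, a 2.1-fold higher number from compound 1 to compound 3 (0.32 log units; beyond the scatter), and compound 2 a higher one, a 5.1-fold lower number from compound 2 to compound 3 (0.71 log units; beyond the scatter). All three share the same core and differ only on the pendant phenyl ring.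

Compound 4, `CC(C)c1cccc(C(C)C)c1NC(=O)NCC1(c2ccc([N+](=O)[O-])cc2)CCCC1`, is the next member. Its change from compound 3 is nitro in place of methoxy on an aromatic carbon. Going by the values given here, the only measured step at that same aromatic carbon is the move from neopentyl to methoxy, a 5.1-fold lower number from compound 2 to compound 3 (0.71 log units; beyond the scatter), which shows that the group at this position can shift the number by a modest amount. Among the compounds with values here, no step shows what a nitro group does here, so the direction is uncertain. Because a 5.1-fold lower number from compound 2 to compound 3 (0.71 log units; beyond the scatter) showed that a smaller group at this carbon gave a lower number, and nitro is also a small group, compound 4 is expected to stay close to compound 3, with a small step of a 1.5-fold higher number from compound 3 to compound 4 (0.16 log units; within the scatter) estimated. The estimate for compound 4 is 45 nM, within 15 nM to 150 nM.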

Compound 4, half-maximal inhibitory concentration: 131 nM
Compound 4: the middle estimate sits 2.9-fold (0.46 log units) below what was measured; measured number inside the range.
By their numbers in this assay, from the lowest: compound 1; then compound 3; then compounds 4 and 2 (each within the scatter of the next).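

In this assay, group size alone no longer accounts for the numbers at this aromatic carbon: replacing methoxy with nitro gives a 4.2-fold higher number from compound 3 to compound 4 (0.63 log units; beyond the scatter), while replacing neopentyl with nitro gives only a 1.2-fold lower number from compound 2 to compound 4 (0.08 log units; within the scatter). The earlier step from neopentyl to methoxy therefore cannot be read as a simple rule that a smaller group gives a lower number, since nitro and neopentyl, very different groups, land within the scatter of each other. The 4-nitrophenyl compound also sits well away from the 3-methylphenyl compound, with an 8.7-fold higher number from compound 1 to compound 4 (0.94 log units; beyond the scatter), so compound 1 keeps the lowest number of the four.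

No measurement at hand explains why methoxy and nitro differ here. From the compounds shown here alone, it remains open whether an amine, a hydroxyl or a chlorine at this carbon would fall nearer compound 3 or compound 4.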